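Chloro to Nitro on a Furanylmethyl Amide Pair

The source may hold more compounds than are shown below. What is called first, only, known or untested is meant among the compounds shown, and "the series" means these compounds.

Three benzoxazolone acetamides have been tested in an ADME assay on RAW264.7 cells (Mus musculus) for cytotoxicity, read by MTT assay, with a stated time of 72 h, tested at 100 uM; on this read-out higher numbers stand for a stronger effect at the one concentration tested and lower numbers for a weaker effect. Compound 1 `O=C(Cn1c(=O)oc2cc(Cl)ccc21)Nc1ccccc1` gives 20.2%, compound 2 `O=C(Cn1c(=O)oc2cc([N+](=O)[O-])ccc21)Nc1ccccc1` gives 26.4%, and compound 3 `O=C(Cn1c(=O)oc2cc(Cl)ccc21)NCc1ccco1` gives 50.3%. The change from compound 1 to compound 2 is nitro in place of chloro on an aromatic carbon, and it gave a number 6.2 percentage points higher from compound 1 to compound 2 (within the scatter). Compound 3 differs from compound 1 by (furan-2-yl)methyl in place of phenyl on an amide-type nitrogen, and that change gave a number 30.1 percentage points higher from compound 1 to compound 3 (beyond the scatter), so compound 3 stands highest of the three and its nearest neighbour is compound 2.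

Compound 4 `O=C(Cn1c(=O)oc2cc([N+](=O)[O-])ccc21)NCc1ccco1` has not yet been measured. It differs from compound 3 by nitro in place of chloro on an aromatic carbon, which is the same change as that from compound 1 to compound 2, made on the same place of a core that differs from the core of compound 1 in the way just described. Because a number 6.2 percentage points higher from compound 1 to compound 2 (within the scatter) was small, the step from compound 3 to compound 4 is expected to be of a similar size, a number 4.7 percentage points higher from compound 3 to compound 4 (within the scatter). Compound 4 is therefore estimated to give about 55% in this assay, with a plausible range from 40% to 70%.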

Compound 4, a percentage reported as inhibition, at one concentration (the size of the read-out at that concentration, not a potency): 60.1%
Estimate against measurement, compound 4: 5.1 percentage points below, and the stated range covers the measured number.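

In this assay nitro in place of chloro on the (furan-2-yl)methyl amide gave a number 9.8 percentage points higher from compound 3 to compound 4 (within the scatter) and, set beside the earlier step on the phenyl amide, it carries from one core to the other without a difference that can be told apart: the same change on two cores in this assay, a number 6.2 percentage points higher (within the scatter) from compound 1 to compound 2 and a number 9.8 percentage points higher (within the scatter) from compound 3 to compound 4, 3.6 percentage points apart, within the scatter of two such steps.

The amide change carries as well, since (furan-2-yl)methyl in place of phenyl gave a number 33.7 percentage points higher from compound 2 to compound 4 (beyond the scatter) and so stays large with nitro as it was with chloro: the same change on two cores in this assay, a number 30.1 percentage points higher (beyond the scatter) from compound 1 to compound 3 and a number 33.7 percentage points higher (beyond the scatter) from compound 2 to compound 4, 3.6 percentage points apart, within the scatter of two such steps.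

Going by these compounds alone, this does not show a rule beyond these four compounds, as each change is seen on only two cores and both nitro steps lie within the scatter, so the nitro change itself cannot be told from no change.

The compounds shown leave open whether an amine or a methoxy group on the same aromatic carbon, or a longer alkyl chain or a benzyl group on the amide nitrogen, would follow the same pattern. They also leave open how these steps would look at any concentration other than the one tested.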